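Methoxy Gives Way to Nitro on a Benzylamine Arm

The compounds below may be only part of what the source reports. "The series", "measured", "known", "first", "only" and "open" are said of these compounds alone.

The series rests on two measured compounds. Compound 1 `C=C1CC[C@@H]2[C@](C)(CO)[C@H](O)CC[C@@]2(C)[C@@H]1CCC1C(=O)OC[C@H]1O` carries a hydroxymethyl group on the shared core and a saturated side chain. In a functional assay on BMMC cells (Mus musculus, strain C57BL/6) for inhibition, with stated times of 5 days and 48 h (on this read-out higher numbers stand for weaker inhibition and lower numbers for stronger inhibition), compound 1 gives only a limit, > 30000 nM. That result sits at the limit of > 30000 nM in this assay, at which 1 of the 2 values shown sits, and is not a number. Among the compounds with values here, compound 2 `C=C1CC[C@@H]2[C@](C)(CNCc3ccc(OC)cc3)[C@H](O)CC[C@@]2(C)[C@@H]1/C=C/C1=CCOC1=O` bears a (4-methoxybenzyl)amino group and an unsaturated side chain; in this assay compound 2 gives 750 nM, the only number recorded in that assay, so compound 2 stands alone among the measured values.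

Compound 3 `C=C1CC[C@@H]2[C@](C)(CNCc3ccc([N+](=O)[O-])cc3)[C@H](O)CC[C@@]2(C)[C@@H]1/C=C/C1=CCOC1=O` has not been measured. It differs from compound 2 by nitro in place of methoxy on an aromatic carbon. Within the data shown here, no measured step between two compounds differing in one place is available to gauge this change, so the expected step is a 1.2-fold higher number from compound 2 to compound 3 (0.08 log units; within the scatter), a shift not exceeding the usual scatter. Compound 3 is accordingly estimated at 900 nM, between 300 nM and 3000 nM.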

Compound 3, half-maximal inhibitory concentration: 1340 nM
Beside the measured number, compound 3's estimate is 1.5-fold (0.17 log units) below it; the range from low to high includes it.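

In this assay, within the data shown here, the change from (4-methoxybenzyl)amino to (4-nitrobenzyl)amino gives a 1.8-fold higher number from compound 2 to compound 3 (0.25 log units; within the scatter), the first step between two compounds that differ in one place. On this read-out, compound 2 and compound 3 cannot be told apart, so methoxy and nitro on this aromatic carbon, para to a large group, read alike even though the two groups differ in their atoms. Nothing shown here bears on why these two groups read alike.

As far as these compounds go, it remains open whether other groups at this place, such as an amine, a carboxylic acid or a simple hydrogen, would also read alike. Also open, from the compounds shown here alone, is what the arm and the side chain each contribute: compound 1 differs from compound 2 in both, and its result is only a limit.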